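Replacing an Amide Substituent: An Estimate for Compound 3

This account rests on a few compounds, and the source may have more. Where it says the series, first, only, none or still open, it means among the compounds named here.

Measured in a functional assay on Jurkat cells (Homo sapiens) for inhibition, read by MTT assay, with a stated time of 72 h; a higher number here means a weaker inhibitor, a lower number a stronger inhibitor:
compound 1 `C=C(Br)C(=O)Nc1cccc(/C=C/C(=O)Nc2ccc(F)cc2)c1`: 6200 nM
compound 2 `C=C(Br)C(=O)Nc1cccc(/C=C/C(=O)Nc2ccc(Cl)cc2)c1`: 2600 nM

Of the two measured compounds, compound 2, at 2600 nM, has the lower number. Compound 3 `C=C(Br)C(=O)Nc1cccc(/C=C/C(=O)NCc2ccc(C)cc2)c1` differs from it in one place: 4-methylbenzyl in place of 4-chlorophenyl on an amide-type nitrogen. Here, 4-methylbenzyl stands in place of 4-chlorophenyl on an amide-type nitrogen. Among the compounds with values here, only one measured step offers any guide, a 2.4-fold lower number from compound 1 to compound 2 (0.38 log units; beyond the scatter), and that modest step is chloro in place of fluoro on an aromatic carbon. Within the data shown here, no measured pair tests a replacement of the kind seen in compound 3, so that step gives only a rough idea of size and no direction. In this assay, no change beyond the scatter is therefore expected, and the estimated step is a 1.3-fold higher number from compound 2 to compound 3 (0.13 log units; within the scatter). For compound 3 the estimate is 3500 nM, with an expected range of 1000 nM to 10000 nM.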

Compound 3, half-maximal inhibitory concentration: 740 nM
For compound 3 the middle estimate is 4.7-fold (0.67 log units) above the measured one; measured number outside the range, below it.
By their numbers in this assay, from the lowest: compound 3; then compound 2; then compound 1.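

In this assay, the group on the amide-type nitrogen emerges as a place where a single replacement moves the number further than the earlier halogen exchange did: 4-methylbenzyl in place of 4-chlorophenyl gives a 3.5-fold lower number from compound 2 to compound 3 (0.55 log units; beyond the scatter) and in place of 4-fluorophenyl gives an 8.4-fold lower number from compound 1 to compound 3 (0.92 log units; beyond the scatter) in the same assay. Both pairs point the same way, with the 4-methylbenzyl compound carrying the lower number, whichever halogen-bearing phenyl it replaces. No measured evidence here bears on why this replacement lowers the number.

The replacement alters two things at once, adding a carbon link to the nitrogen and exchanging the halogen on the ring for methyl, and the compounds shown do not separate these. A 4-chlorobenzyl or an unsubstituted benzyl group on the same nitrogen would address that question, while a longer chain such as 2-phenylethyl would show whether further extension changes the number.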